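One Chloro Traded for Trifluoromethyl in a Cell Assay

The source may report more compounds than this note shows. Statements on the series, on what has been measured and on what is new or still open speak of the compounds shown alone.

Compound 1 `COc1cc(-c2nn(-c3cccc(NC(=O)Nc4ccc(Cl)c(Cl)c4)c3)cc2-c2ccncc2)ccc1Cl` was tested in a functional assay on TK-10 cells (Homo sapiens) for inhibition, read by sulforhodamine B assay, with a stated time of 48 h; a higher number here means that more compound is tolerated, a lower number that less compound is tolerated. In this assay compound 1 gives > 50000 nM, which is a limit of the assay rather than a measured number. Compound 2 `O=C(Nc1cccc(-n2cc(-c3ccncc3)c(-c3ccc(Cl)c(O)c3)n2)c1)Nc1ccc(Cl)c(Cl)c1` differs from compound 1 by hydrogen in place of methyl on an oxygen on an aromatic ring. In this assay compound 2 gives > 32500 nM, again a limit. The step that the two limits leave unreadable from compound 1 to compound 2 is therefore not readable. Among the measured compounds shown here, compound 3 `O=C(Nc1cccc(-n2cc(-c3ccncc3)c(-c3ccc(Cl)c(O)c3)n2)c1)Nc1cc(C(F)(F)F)cc(C(F)(F)F)c1` is the only compound with a number here: in this assay compound 3 gives 14200 nM.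

Compound 4 `COc1cc(-c2nn(-c3cccc(NC(=O)Nc4ccc(Cl)c(C(F)(F)F)c4)c3)cc2-c2ccncc2)ccc1Cl` has not been measured. It differs from compound 1 in trifluoromethyl in place of chloro on an aromatic carbon. For the measured compounds named here, no measured step covers this change, and the single step available, from compound 1 to compound 2, lies between the limit of > 50000 nM in this assay, at which 1 of the 3 values shown sits, and (the limit of > 32500 nM in this assay, at which 1 of the 3 values shown sits). For compound 4 the expected step is an at least 1.2-fold lower number from compound 1 to compound 4 (0.09 log units; that floor lies within the scatter), not beyond the scatter. Compound 4 is therefore estimated at 40000 nM, between 15000 nM and 100000 nM, and most probably the assay will again report a limit.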

Compound 4, concentration lethal to 50% of the cells: > 32500 nM
Compound 4: a limit, no number (the forecaster's own chance of this, stated with the estimate: 60%); the middle value is on the limit's open side.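

Compound 1 and compound 4 each give only a limit of the assay, not a number, in this assay, so no step can be read between them. The compounds shown leave open whether trifluoromethyl in place of chloro changes the result at all, and by how much.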